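A Methylamino Swap Between Two Inactive Nucleosides

The source may hold more compounds than are shown below. What is called first, only, known or untested is meant among the compounds shown, and "the series" means these compounds.

Compound 1 `CNc1ncnc2c1c(-c1ccccc1)cn2[C@@H]1O[C@H](CO)[C@@H](O)[C@H]1O`: > 20000 nM
Compound 2 `Cc1ncnc2c1c(-c1cc3ccccc3o1)cn2[C@@H]1O[C@H](CO)[C@@H](O)[C@H]1O`: > 20000 nM

In a functional assay on A549 cells (Homo sapiens), read by MTT assay, with a stated time of 72 h (a lower number here means a stronger inhibitor, a higher number a weaker inhibitor), compound 1 gives > 20000 nM, a limit of the assay rather than a number. Compound 2 gives > 20000 nM in this assay, likewise only a limit. Compound 2 thus sits at the limit of > 20000 nM in this assay, at which 2 of the 2 values shown sit. Compound 3 `CNc1ncnc2c1c(-c1cc3ccccc3o1)cn2[C@@H]1O[C@H](CO)[C@@H](O)[C@H]1O` differs from compound 2 in one place: methylamino in place of methyl on an aromatic carbon. Among the measured compounds shown here, no measured pair shows this change, so no step can be read from the data. Compound 3 is expected to remain near the same limit, with an expected step that the limit leaves unreadable from compound 2 to compound 3. Compound 3 is estimated at 25000 nM, within 6000 nM to 100000 nM.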

Compound 3, half-maximal inhibitory concentration: > 20000 nM
Compound 3: only a limit was reported (the forecaster's own chance of this, stated with the estimate: 75%); the middle value does not contradict the limit.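

Compound 3 stays at the assay limit, as do compound 1 and compound 2, so neither its step from compound 2 nor its step from compound 1 can be read: the limit of > 20000 nM in this assay, at which 3 of the 3 values shown sit.

From the compounds shown here alone, whether either change alters activity in this assay at all remains open.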